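The source may report more compounds than this note shows. Statements on the series, on what has been measured and on what is new or still open speak of the compounds shown alone.

Within the data shown here, compound 1 `CCc1nc(-c2ccc(Cl)cc2Cl)c(CC)nc1CC(CC)CC` is one of two compounds measured in an assay on IMR-32 cells for displacement of a labelled ligand from corticotropin-releasing factor receptor 1 (Homo sapiens), read by scintillation counting, with a stated time of 2 h; on this read-out lower numbers stand for stronger inhibition and higher numbers for weaker inhibition. In this assay compound 1 gives 68 nM, the higher of the two numbers shown, so it is the weaker binder of the pair. The other measured compound, compound 2 `CCc1nc(-c2ccc(OC(F)(F)F)cc2OC)c(CC)nc1NC(CC)CC`, differs from it in more than one place and gives 7.2 nM in this assay, a gap beyond the scatter.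

Compound 3 `CCc1nc(-c2ccc(Cl)cc2Cl)c(CC)nc1NC(C1CC1)C1CC1` has not yet been measured. It keeps the core and the 2,4-dichlorophenyl group of compound 1 but carries a different side chain: (dicyclopropylmethyl)amino in place of 2-ethylbutyl on an aromatic carbon.

An amino-linked branched group of this kind appears in compound 2, which gives 7.2 nM in this assay, so the change is expected to lower the number from compound 1 to compound 3 by a 6.8-fold lower number from compound 1 to compound 3 (0.83 log units; beyond the scatter). For compound 3 the expected value in this assay is 10 nM, with a likely range from 2 nM to 50 nM.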

Compound 3, inhibition constant: 3.7 nM
Beside the measured number, compound 3's estimate is 2.7-fold (0.43 log units) above it; measured number inside the range.
By their numbers in this assay, from the lowest: compounds 3 and 2 (each within the scatter of the next); then compound 1.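

With the core and the 2,4-dichlorophenyl group held fixed, placing (dicyclopropylmethyl)amino instead of 2-ethylbutyl on this aromatic carbon gives an 18-fold lower number from compound 1 to compound 3 (1.26 log units; beyond the scatter) in this assay and so counts as a large step. Among these compounds, the earlier pair differed in more than one place, so this is the first comparison that ties a change in the number to this side chain alone. The swap brings in the amino link and the two three-membered rings together, and no measurement shown explains the gain.

As far as these compounds go, whether the step follows the nitrogen link or the rings remains open. A dicyclopropylmethyl group joined directly through carbon, or a dicyclopropylmethoxy group joined through oxygen, at this position would help separate the two.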